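This account rests on a few compounds, and the source may have more. Where it says the series, first, only, none or still open, it means among the compounds named here.

Measured so far in a functional assay on HeLa S3 cells (Homo sapiens) for antiproliferative activity, read by XTT assay, with a stated time of 72 h; on this read-out higher numbers stand for weaker inhibition and lower numbers for stronger inhibition:
- compound 1 `Nc1nc(N)c2c(-c3cccs3)cn([C@@H]3O[C@H](CO)[C@@H](O)[C@H]3O)c2n1`: > 20000 nM (a limit)
- compound 2 `Nc1nc2c(c(-c3ccco3)cn2[C@@H]2O[C@H](CO)[C@@H](O)[C@H]2O)c(=O)[nH]1`: > 20000 nM (a limit)

Going by the values given here, neither compound has a numerical value, so the series so far consists of the limit of > 20000 nM in this assay, at which 2 of the 2 values shown sit. As far as these compounds go, compound 2 therefore stands at a limit and not at a number, and its true position in this assay remains open.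

The next compound is compound 3 `Nc1nc2c(c(-c3cc4ccccc4o3)cn2[C@@H]2O[C@H](CO)[C@@H](O)[C@H]2O)c(=O)[nH]1`, with this change from compound 2: 1-benzofuran-2-yl in place of furan-2-yl on an aromatic carbon. In short, 1-benzofuran-2-yl stands in place of furan-2-yl on an aromatic carbon, and the rest of the structure is unchanged.

Among the compounds with values here, no step between measured compounds is available to size this change. The expectation in this assay is therefore for no step beyond the scatter, with only a modest chance of stronger inhibition. This expectation rests on compound 2, whose > 20000 nM is a limit. The step expected is a number no higher from compound 2 to compound 3 (the limit leaves the size open). For compound 3 the estimated value is 20000 nM. The expected range for that estimate runs from 6000 nM to 40000 nM.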

Compound 3, half-maximal inhibitory concentration: > 20000 nM
Compound 3: a limit, no number; the forecaster's own chance of this, stated with the estimate: 75%; the middle value sits exactly at the limit.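

In this assay compound 3 gives > 20000 nM, a limit and not a number. Compound 2 also stands at a limit, so no step can be read from compound 2 to compound 3. The series so far rests on one value: the limit of > 20000 nM in this assay, at which 3 of the 3 values shown sit.

The compounds shown leave open where any of them truly lies in this assay, and whether any change to the shared core gives a numerical value there.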